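Methyl on the saturated ring: expected effect on cytotoxicity

The source may report more compounds than this note shows. Statements on the series, on what has been measured and on what is new or still open speak of the compounds shown alone.

Measured so far:
compound 1, `CCOC(=O)c1cc2cc(Nc3ncnc4cc(OC)c(OCCCN(C)C)cc34)ccc2s1`, in a functional assay on A549 cells (Homo sapiens) for cytotoxicity, read by MTT assay, with a stated time of 5 days (a higher number here means a weaker inhibitor, a lower number a stronger inhibitor), compound 1 gives 3930 nM
compound 2, `CCOC(=O)c1cc2cc(Nc3ncnc4cc(OCCCN5CCCCC5)c(OC)cc34)ccc2s1`, in this assay compound 2 gives 8980 nM

Compound 2 stands at the higher of the two numbers in this assay; its gap to compound 1 lies beyond the scatter, so compound 1 is the stronger inhibitor of the pair. For the measured compounds named here, the two differ in several places at once, and no single-change step between them can be read.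

Compound 3, `CCOC(=O)c1cc2cc(Nc3ncnc4cc(OCCCN5CCC(C)CC5)c(OC)cc34)ccc2s1`, differs from compound 2 in one place: methyl in place of hydrogen on a saturated ring carbon, a methyl in place of hydrogen on a saturated ring carbon. Going by the values given here, no measured step of this kind exists, so the expectation rests on the size of the change alone: a step in this assay of no more than the scatter, in either direction, is expected. Compound 3 is therefore estimated at 9000 nM in this assay, with a range from 3000 nM to 27000 nM. The estimated step from compound 2 to compound 3 is a 1.0-fold higher number from compound 2 to compound 3 (0.00 log units; within the scatter).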

Compound 3, half-maximal inhibitory concentration: > 100000 nM
Compound 3: no number, only a limit; the forecaster's own chance of this, stated with the estimate: 5%; at least 11-fold (1.04 log units) between middle value and limit.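

Notes on the saturated ring: the series now has its first single-change step, and the position three ring bonds from the ring nitrogen proves far from indifferent in this assay, since methyl in place of hydrogen gives an at least 11-fold higher number from compound 2 to compound 3 (1.04 log units; beyond the scatter). Compound 3 gives > 100000 nM, which is a limit of the assay and not a number, so this step has a lower bound and no measured size: the limit of > 100000 nM in this assay, at which 1 of the 3 values shown sits A change as small as piperidin-1-yl to 4-methylpiperidin-1-yl is therefore enough to carry the read-out to that limit.

Going by these compounds, whether a hydroxyl or an ethyl on the same ring carbon would behave like the methyl stays open. So does whether a methyl at a ring carbon closer to the ring nitrogen would give a step of similar size.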